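The compounds below may be only part of what the source reports. "The series", "measured", "known", "first", "only" and "open" are said of these compounds alone.

Measured in a functional assay on DLA cells (Mus musculus) for cytotoxicity, read by MTT assay, with a stated time of 48 h; on this read-out lower numbers stand for stronger inhibition and higher numbers for weaker inhibition:

- compound 1 `COc1ccc(-c2csc(NC(=O)COc3ccc(C(=O)c4ccc(C)cc4)cc3C)n2)cc1`: 17200 nM
- compound 2 `Cc1cc(C(=O)c2cccc(Br)c2)ccc1OCC(=O)Nc1nc(-c2ccccc2)cs1`: 23800 nM

Compound 2 has the highest of the two numbers in this assay, but its nearest neighbour is compound 1, whose number is lower by an amount that stays within the scatter, so the two compounds cannot be told apart on this read-out. Compound 3 `COc1ccc(-c2csc(NC(=O)COc3ccc(C(=O)c4cccc(Br)c4)cc3C)n2)cc1` has not yet been measured. It differs from compound 2 in one place: methoxy in place of hydrogen on an aromatic carbon. Among the compounds with values here, no step between measured compounds that differ in exactly this way has been recorded, so the effect of the change has to be judged from the two numbers alone. Compound 1 carries the same methoxy group on its own phenyl ring and does not stand apart from compound 2 beyond the scatter, which gives no sign that this group moves the number much in either direction. For compound 3 the step of a 1.2-fold lower number from compound 2 to compound 3 (0.08 log units; within the scatter) is therefore expected to be small, with no clear direction beyond the scatter. Compound 3 is estimated to give about 20000 nM in this assay, within a range from 8000 nM to 50000 nM.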

Compound 3, half-maximal inhibitory concentration: 36600 nM
Compound 3: the middle estimate sits 1.8-fold (0.26 log units) below what was measured, and the stated range covers the measured number.
By their numbers in this assay, from the lowest: compounds 1, 2 and 3 (each within the scatter of the next, the first and the last beyond it).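

In this assay the change of methoxy in place of hydrogen on an aromatic carbon, para to a large group, now has a measured step, a 1.5-fold higher number from compound 2 to compound 3 (0.19 log units; within the scatter), so compound 2 and compound 3 cannot be told apart and this phenyl to 4-methoxyphenyl change shows no effect that can be read on this background. Within the data shown here, the change of 3-bromophenyl in place of 4-methylphenyl on a carbonyl carbon gives the only step so far to pass the scatter, modestly, with a 2.1-fold higher number from compound 1 to compound 3 (0.33 log units; beyond the scatter), which suggests that the group on the carbonyl carbon may matter more than the methoxy, although this single pair is all that supports the idea. No measured evidence bears on why either step has the size it has.

Going by these compounds, whether an amine, a hydroxyl or a carboxylic acid at the same ring position would shift the number beyond the scatter remains open. On these data alone, it is also open whether the step on the carbonyl carbon would hold on the phenyl compounds that lack the methoxy, or with a chloro or a longer alkyl chain on that ring.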